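A few compounds are considered here, and "the series" means these few. Any claim that something is new, unique, unknown or untested is made for them only; others in the source may bear on it.

Going by the values given here, compound 3 `CC(=O)N1N=C(c2cccc3ccccc23)CC1c1cccc(Cl)c1Cl` stands second highest among the three numbers so far in a functional assay on PC-3 cells (Homo sapiens) for cytotoxicity, read by sulforhodamine B assay, with a stated time of 48 h (on this read-out lower numbers stand for stronger inhibition and higher numbers for weaker inhibition), where compound 3 gives 20100 nM. Compound 1 `COc1ccc(C2CC(c3ccco3)=NN2C(C)=O)cc1` gives 15500 nM, within the scatter of compound 3, while compound 2 `CC(=O)N1N=C(c2ccco2)CC1c1cccc(Cl)c1Cl` gives 61200 nM, a higher number than compound 3 by a margin beyond the scatter. Compound 4 `COc1ccc(C2CC(c3cccc4ccccc34)=NN2C(C)=O)cc1` carries 4-methoxyphenyl in place of 2,3-dichlorophenyl on a saturated ring carbon. Among the compounds with values here, no measured pair here provides a direct step, but compound 1 and compound 2 differ in the same way, and compound 1 returns the lower number of the two. On that basis compound 4 is expected to show a step of a 2.5-fold lower number from compound 3 to compound 4 (0.40 log units; beyond the scatter), toward stronger inhibition in this assay. The estimate for compound 4 is 8000 nM, with a range from 3000 nM to 25000 nM.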

Compound 4, half-maximal inhibitory concentration: 4930 nM
The estimate for compound 4 lay 1.6-fold (0.21 log units) above the measured number, and the stated range covers the measured number.
By their numbers in this assay, from the lowest: compound 4; then compounds 1 and 3 (each within the scatter of the next); then compound 2.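

In this assay the change at this saturated ring carbon can now be read directly: 4-methoxyphenyl in place of 2,3-dichlorophenyl gives a 4.1-fold lower number from compound 3 to compound 4 (0.61 log units; beyond the scatter) and stronger inhibition. The same exchange points the same way in the furan-bearing pair, where compound 2 gives 61200 nM against 15500 nM for compound 1 in this assay and the lower number again goes with 4-methoxyphenyl. Nothing measured here accounts for the step.

Still open, from the compounds shown here alone, is whether the methoxy group or the loss of the two chlorines drives the step. A plain phenyl or a 4-hydroxyphenyl at this carbon would help separate the two.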